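Butyl for Isopropyl: One Change, One Expected Dose

The source may report more compounds than this note shows. Statements on the series, on what has been measured and on what is new or still open speak of the compounds shown alone.

Compound 1 `CCc1nn(C)c2c1C(c1ccc(F)cc1)=NCC(=O)N2C`: > 500 mg/kg
Compound 2 `CC(C)c1nn(C)c2c1C(c1ccccc1Cl)=NCC(=O)N2`: 125 mg/kg

All measurements come from a functional assay on the whole organism with Rattus norvegicus as the target; on this read-out lower numbers stand for an effect already at smaller amounts and higher numbers for an effect only at larger amounts of compound. In this assay compound 1 gives only a limit, > 500 mg/kg, so no number is known for it. For the measured compounds named here, compound 2 stands at 125 mg/kg, the only number in the set. Going by the values given here, the one other value, that of compound 1, is a limit: the limit of > 500 mg/kg in this assay, at which 1 of the 2 values shown sits.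

Compound 3 `CCCCc1nn(C)c2c1C(c1ccccc1Cl)=NCC(=O)N2` has not yet been measured in this assay. It differs from compound 2 in one place: butyl in place of isopropyl on an aromatic carbon. Among the compounds with values here, no step between two measured compounds that differ in one place is available, so the expectation rests on compound 2 alone. A step beyond the usual scatter is not expected in either direction; the expected step of a 1.2-fold higher number from compound 2 to compound 3 (0.08 log units; within the scatter) is small. Compound 3 is therefore estimated at 150 mg/kg, with a range from 60 mg/kg to 400 mg/kg.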

Compound 3, minimum effective dose: > 500 mg/kg
Compound 3: only a limit was reported; the forecaster's own chance of this, stated with the estimate: 20%; middle value at least 3.3-fold (0.52 log units) from the limit.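

In this assay, butyl in place of isopropyl on this aromatic carbon gives an at least 4.0-fold higher number from compound 2 to compound 3 (0.60 log units; beyond the scatter), so this one change at this position is enough to move the read-out beyond the scatter. Compound 1 and compound 2 differ in more than one place and could not show this, whereas the present pair isolates the effect of the chain at this position. The value of compound 3, > 500 mg/kg, is a limit.

The full size of the step remains unknown because compound 3 gives no number, only a limit: the limit of > 500 mg/kg in this assay, at which 2 of the 3 values shown sit.

Going by these compounds, it also remains open whether a propyl chain, a cyclopropyl ring or an amine at this position would stay close to compound 2 or move as far as butyl does.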